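The compounds below may be only part of what the source reports. "The series", "measured", "known", "first", "only" and "open" are said of these compounds alone.

Measured so far:
Compound 1 `COc1ccc(Nc2nc(-c3cccc(F)c3)nc3ccc(F)cc23)cc1`: in a functional assay on U-937 cells (Homo sapiens) for cytotoxicity, read by MTT assay, with a stated time of 48 h (on this read-out lower numbers stand for stronger inhibition and higher numbers for weaker inhibition), compound 1 gives 41100 nM.
Compound 2 `Fc1cccc(-c2nc(Nc3cccc(Br)c3)c3cc(F)ccc3n2)c1`: in this assay compound 2 returns only > 50000 nM, which is a limit of the assay and not a number.

Compound 2 thus stands at the ceiling of what the assay resolves, whereas compound 1 has a number of its own. For the measured compounds named here, the single measured step, an at least 1.2-fold higher number from compound 1 to compound 2 (0.08 log units; that floor lies within the scatter), swaps the group on the nitrogen on an aromatic ring and ends on the limit, as recorded in the limit of > 50000 nM in this assay, at which 1 of the 2 values shown sits. The unmeasured compound 3 `Fc1cccc(-c2nc(Nc3ccccc3Br)c3cc(F)ccc3n2)c1` differs from compound 2 by 2-bromophenyl in place of 3-bromophenyl on a nitrogen on an aromatic ring. Going by the values given here, no measured step covers moving the bromine around the same phenyl ring, so the measured step bears on it only indirectly: it shows that this amino substituent already carries the half-maximal inhibitory concentration out of the readable range. With nothing pointing to a gain, the expectation in this assay is that compound 3 again lands at or beyond the limit, so the step that the limit leaves unreadable from compound 2 to compound 3 is estimated as none beyond the scatter. Compound 3 is therefore estimated at 60000 nM, with a range from 25000 nM to 150000 nM.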

Compound 3, half-maximal inhibitory concentration: > 50000 nM
Compound 3 was reported as a limit; the forecaster's own chance of this, stated with the estimate: 70%; the middle value does not contradict the limit.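

In this assay, compound 3 also gives a limit and not a number, so the move from 3-bromophenyl to 2-bromophenyl on the nitrogen produces no readable response, and the step between compound 2 and compound 3 cannot be read. Replacing the 4-methoxyphenyl group with 2-bromophenyl gives an at least 1.2-fold higher number from compound 1 to compound 3 (0.08 log units; that floor lies within the scatter); this is only a floor, and it sets no order between the two groups. With two bromine placements now tested, neither brings a bromophenyl compound back into the readable range, and the limit now holds most of the series: the limit of > 50000 nM in this assay, at which 2 of the 3 values shown sit.

Still open, from the compounds shown here alone, is whether any group on this nitrogen can give a clearly lower number than compound 1, at 41100 nM, on the shared core. For the compounds shown here, an unsubstituted phenyl, a pyridyl group or a phenyl ring carrying a carboxylic acid or an amine would test this, and any readable value would give the first step of measurable size at this position.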